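This account rests on a few compounds, and the source may have more. Where it says the series, first, only, none or still open, it means among the compounds named here.

Working notes on the series start from compound 1 (`Fc1ccccc1Cc1nc(-c2nc(C(F)F)n[nH]2)n2ccccc12`). For the measured compounds named here, in an in vitro ADME assay on microsomes from liver (Homo sapiens) for metabolic stability (a lower number here means slower removal, a higher number faster removal of the compound), compound 1 gives 62 mL.min-1.g-1, the only actual number so far. Compound 2 (`Cc1ncc(Cc2nc(-c3nc(C(F)(F)F)n[nH]3)n3ccccc23)cn1`) reads < 8 mL.min-1.g-1, which is a limit of the assay. Compound 3 (`FC(F)(F)c1n[nH]c(-c2nc(Cc3cncnc3)c3ccccn23)n1`) reads < 7 mL.min-1.g-1, which is also a limit.

Going by the values given here, the only measured step is a step that the two limits leave unreadable from compound 2 to compound 3, with hydrogen in place of methyl on an aromatic carbon. That step has no readable size, and it concerns a different change at a different place, so it gives neither a size nor a direction for the question at hand.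

Compound 4 (`CS(=O)(=O)c1n[nH]c(-c2nc(Cc3ccccc3F)c3ccccn23)n1`) keeps the core of compound 1 and carries one change, methylsulfonyl in place of difluoromethyl on an aromatic carbon. Among the compounds with values here, no measured step covers this swap, so the expectation rests on the structural change alone and stays loose. With compound 1 at 62 mL.min-1.g-1, a moderate fall in this assay is expected, with a wide margin on either side. The expected step is a 2.5-fold lower number from compound 1 to compound 4 (0.39 log units; beyond the scatter). Compound 4 is estimated at 25 mL.min-1.g-1, with an expected range of 10 mL.min-1.g-1 to 60 mL.min-1.g-1.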

Compound 4, intrinsic clearance in microsomes: 11 mL.min-1.g-1
Compound 4: the middle estimate sits 2.3-fold (0.36 log units) above what was measured; the range from low to high includes it.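

In this assay, the position on an aromatic carbon of the five-membered aromatic ring with 3 nitrogen, between two ring nitrogen atoms, now has its first readable step: with methylsulfonyl in place of difluoromethyl and the rest of the structure unchanged, the result is a 5.6-fold lower number from compound 1 to compound 4 (0.75 log units; beyond the scatter). For the compounds shown here, the earlier compounds could not show this, since compound 2 and compound 3 differ from compound 1 in more than one place, and the single step between those two cannot be read. This places the group at this position among the changes that can move the number in this assay, though that rests on one pair of compounds and sets no pattern for the series. Nothing at hand bears on why the number falls with this swap.

As far as these compounds go, it remains open whether a nitrile, a carboxylic acid or a primary amide at this position would move the number in the same direction and by a similar size. From the compounds shown here alone, it is also open whether methylsulfonyl would give a comparable step on a compound that carries the other side group of compound 3.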